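Working notes: adding the 2-(4-fluorophenyl)ethoxy group

The compounds below may be only part of what the source reports. "The series", "measured", "known", "first", "only" and "open" are said of these compounds alone.

- compound 1 `CCN(CC)C/C=C/C(=O)NC/C=C/c1cc(OCCc2ccc(F)cc2)cc(O)c1C(=O)OC(C)C` gives 4040 nM in the only assay run
- compound 2 `C/C=C/C(=O)NC/C=C/c1cc(OC)cc(O)c1C(=O)OC(C)C` gives > 10000 nM (a limit of the assay, not a number)

In a functional assay on MV4-11 cells (Homo sapiens) for antiproliferative activity, read by luminescence, with a stated time of 72 h (a lower number here means a stronger inhibitor, a higher number a weaker inhibitor), compound 2 stands at > 10000 nM as a limit and not as a number, so only that limit places it. Compound 3 `C/C=C/C(=O)NC/C=C/c1cc(OCCc2ccc(F)cc2)cc(O)c1C(=O)OC(C)C` is the next to be read. The change from compound 2 is 4-fluorobenzyl in place of hydrogen on a saturated chain carbon bound to an oxygen on an aromatic ring and, cut one bond further out, it reads methoxy to 2-(4-fluorophenyl)ethoxy. No measured step sizes this change. Among the measured compounds shown here, the one guide is compound 1, which carries the same 2-(4-fluorophenyl)ethoxy group and gives 4040 nM in this assay as the only number. A modest gain in potency is therefore expected, though a further limit remains possible. The expected step of an at least 1.6-fold lower number from compound 2 to compound 3 (0.22 log units; that floor lies within the scatter) is an estimate and starts from a limit. Compound 3 is estimated at 6000 nM in this assay with an expected range from 2000 nM to 15000 nM as its span.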

Compound 3, half-maximal inhibitory concentration: > 10000 nM
Compound 3 gave a limit, no number; the forecaster's own chance of this, stated with the estimate: 35%; at least 1.6-fold (0.22 log units) between middle value and limit.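

In this assay the 2-(4-fluorophenyl)ethoxy group without the diethylamino group gives no number, which compound 1 alone could not show. Hydrogen in place of diethylamino on a saturated chain carbon bound to a double-bonded chain carbon gives an at least 2.4-fold higher number from compound 1 to compound 3 (0.39 log units; beyond the scatter) and so ties the measurable activity in this pair to the diethylamino group. Whether methoxy to 2-(4-fluorophenyl)ethoxy has any effect cannot be read, because both compounds in that pair stop at a limit of the assay: the limit of > 10000 nM in this assay, at which 2 of the 3 values shown sit.

Open, as far as these compounds go, is whether the diethylamino group gives a number with methoxy in place of 2-(4-fluorophenyl)ethoxy. Also open, from the compounds shown here alone, is whether another amine at the same place, such as a dimethylamino or pyrrolidine group, keeps the activity of compound 1.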